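Swapping the methoxyphenyl for a dichlorophenyl on the sulfonamide

The compounds below may be only part of what the source reports. "The series", "measured", "known", "first", "only" and "open" are said of these compounds alone.

Compound 1 `COc1ccc(S(=O)(=O)NCCCCCCNCc2ccc(Br)cc2)cc1` gives 13000 nM in a functional assay on MIA PaCa-2 cells (Homo sapiens) for inhibition, read by MTT assay, with a stated time of 72 h; on this read-out lower numbers stand for stronger inhibition of growth and higher numbers for weaker inhibition of growth.
Compound 2 `CCCCc1ccc(S(=O)(=O)NCCCCCCNCc2ccc(Br)cc2)cc1` gives 5700 nM in this assay.
Compound 3 `O=S(=O)(NCCCNCc1ccccc1)c1cc(C(F)(F)F)cc(C(F)(F)F)c1` gives 11000 nM in this assay.

Among these three, compound 1 has the highest number; compound 3 sits within the usual scatter of it, while compound 2 lies clearly lower, by a 2.3-fold lower number from compound 1 to compound 2 (0.36 log units; beyond the scatter). Compound 4 `O=S(=O)(NCCCCCCNCc1ccc(Br)cc1)c1c(Cl)cccc1Cl` is the next candidate. The change is 2,6-dichlorophenyl in place of 4-methoxyphenyl on a sulfonyl sulfur. Among the measured compounds shown here, only one measured step touches the same place: the step from compound 1 to compound 2, which removed the methoxy group and gave a modestly lower number. Compound 3 differs in both its chain and its aromatic group on the sulfonyl, so it offers no clean comparison. A modest lowering is therefore expected, about a 1.6-fold lower number from compound 1 to compound 4 (0.21 log units; within the scatter). For compound 4 the estimated value in this assay is 8000 nM, with a range from 3000 nM to 20000 nM.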

Compound 4, concentration for 50% growth inhibition: 14700 nM
Compound 4: the middle estimate sits 1.8-fold (0.26 log units) below what was measured, and the stated range covers the measured number.
By their numbers in this assay, from the lowest: compounds 2, 3, 1 and 4 (each within the scatter of the next, the first and the last beyond it).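

In this assay, 2,6-dichlorophenyl in place of 4-methoxyphenyl on the sulfonyl sulfur gives a 1.1-fold higher number from compound 1 to compound 4 (0.05 log units; within the scatter), so this position takes a quite different aromatic group with no clear change in the number. The lowering seen with butyl, a 2.3-fold lower number from compound 1 to compound 2 (0.36 log units; beyond the scatter), is not repeated by this swap. No measurement available here explains why the two groups give such similar numbers.

On these data alone, it remains open whether an amine or a carboxylic acid on this aromatic ring, or a longer chain in place of the butyl, would shift the number further.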